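A few compounds are considered here, and "the series" means these few. Any claim that something is new, unique, unknown or untested is made for them only; others in the source may bear on it.

Measured compounds:
compound 1 `O=C1C[C@H]2O[C@H](Cc3ccccc3)[C@H](OCc3ccccc3)[C@H]2O1` gives 9480 nM in a functional assay on Raji cells (Homo sapiens) for antiproliferative activity, read by MTT assay, with a stated time of 72 h; on this read-out higher numbers stand for weaker inhibition and lower numbers for stronger inhibition
compound 2 `O=C1C[C@@H]2O[C@H]3[C@H](c4ccccc4)c4ccccc4CO[C@H]3[C@@H]2O1` gives 15900 nM in this assay

Compound 1 holds the lower of the two numbers, yet its gap to compound 2 lies within the usual scatter, so the two are not told apart. Compound 3 `O=C1C[C@H]2O[C@H](Cc3ccccc3)[C@H](O)[C@H]2O1` differs from compound 1 by one change: hydrogen in place of benzyl on an oxygen on a saturated carbon. For the measured compounds named here, no comparable step has been measured, so there is nothing to lean on; a step of a 1.6-fold higher number from compound 1 to compound 3 (0.20 log units; within the scatter) is expected, small and not clearly beyond the scatter. Compound 3 is therefore expected to give about 15000 nM, within 5000 nM to 50000 nM.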

Compound 3, half-maximal inhibitory concentration: 1030 nM
Compound 3: the middle estimate sits 15-fold (1.16 log units) above what was measured, and the stated range ends above it.
By their numbers in this assay, from the lowest: compound 3; then compounds 1 and 2 (each within the scatter of the next).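

Going from benzyloxy to hydroxy on the saturated carbon brings a 9.2-fold lower number from compound 1 to compound 3 (0.96 log units; beyond the scatter) in this assay and thus shows that this position responds to a single change, which the two earlier compounds could not show. The benzyl is not needed for this activity, and compound 3 stands clear of compound 1 on this one pair. Nothing measured here explains the step. The compounds shown leave open whether the hydroxy itself matters or only the loss of the benzyl, as neither a methoxy group nor an amine appears at this position.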